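The source may hold more compounds than are shown below. What is called first, only, known or untested is meant among the compounds shown, and "the series" means these compounds.

Compound 1 `CCNC(=O)c1cc(N)c(Nc2ccc(C#N)cc2)cc1Oc1c(C)cc(/C=C/C#N)cc1C` is the longer-lived of the two measured compounds: in an ADME assay on a cell-free system (plasma, Homo sapiens) for metabolic stability, read by LC-MS, tested at 10 ug/mL (on this read-out higher numbers stand for a longer-lived compound and lower numbers for a shorter-lived compound), compound 1 gives 91 h, whereas compound 2 `Cc1cc(/C=C/C#N)cc(C)c1Oc1cc(Nc2ccc(C#N)cc2)c(N)cc1C(=O)NN` gives 8 h, a change of an 11-fold lower number from compound 1 to compound 2 (1.06 log units; beyond the scatter). Compound 3 `Cc1cc(/C=C/C#N)cc(C)c1Oc1cc(Nc2ccc(C#N)cc2)c(N)cc1C(=O)OCCC#N` differs from compound 1 by 2-cyanoethoxy in place of ethylamino on a carbonyl carbon. Among the measured compounds shown here, no measured step shows this exact change; the only step at the carbonyl carbon, from compound 1 to compound 2, was large and downward, so a decrease of similar scale is expected for compound 3, with wide uncertainty. Compound 3 is therefore estimated at 20 h, within 4 h to 80 h, meaning an expected step of a 4.6-fold lower number from compound 1 to compound 3 (0.66 log units; beyond the scatter).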

Compound 3, half-life: 32 h
For compound 3 the middle estimate is 1.6-fold (0.20 log units) below the measured one; measured number inside the range.
By their numbers in this assay, from the lowest: compound 2; then compound 3; then compound 1.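

At the carbonyl carbon, 2-cyanoethoxy in place of ethylamino gives a 2.8-fold lower number from compound 1 to compound 3 (0.45 log units; beyond the scatter) while 2-cyanoethoxy in place of aminoamino gives a 4.0-fold higher number from compound 2 to compound 3 (0.60 log units; beyond the scatter) at the same atom. The group on this carbonyl carbon therefore sets the number over a graded range, and compound 3 falls on neither extreme among the three compounds. Nothing at hand explains this order. Still open, on these data alone, is how a simple ethoxy, a 2-cyanoethylamino group or a carboxylic acid on this carbonyl carbon would compare. Also open, as far as these compounds go, is whether the oxygen or the nitrile of 2-cyanoethoxy matters more.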